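The source may report more compounds than this note shows. Statements on the series, on what has been measured and on what is new or still open speak of the compounds shown alone.

Compound 1 `Cc1cc(S(=O)(=O)/N=C(\N)n2nccc2-c2ccccc2)c(SCc2cccc(Cl)c2)cc1Cl`: 10000 nM
Compound 2 `Cc1cc(S(=O)(=O)/N=C(\N)n2nccc2-c2ccccc2)c(SCc2ccccc2)cc1Cl`: 5000 nM
Compound 3 `Cc1cc(S(=O)(=O)/N=C(\N)n2nccc2-c2ccccc2)c(SCc2cccc(C(F)(F)F)c2)cc1Cl`: 19000 nM

Of the compounds shown here, three built on one shared core have so far been tested in a functional assay on HeLa cells (Homo sapiens) for cytotoxicity, read by MTT assay, with a stated time of 72 h; on this read-out higher numbers stand for weaker inhibition and lower numbers for stronger inhibition. Compound 3 stands at the highest of the three numbers: its nearest neighbour is compound 1, separated by a 1.9-fold higher number from compound 1 to compound 3 (0.28 log units; within the scatter), and its furthest is compound 2, separated by a 3.8-fold higher number from compound 2 to compound 3 (0.58 log units; beyond the scatter). Compound 4 `Cc1ccc(CSc2cc(Cl)c(C)cc2S(=O)(=O)/N=C(\N)n2nccc2-c2ccccc2)cc1` has not yet been measured. It differs from compound 3 in one place: 4-methylphenyl in place of 3-(trifluoromethyl)phenyl on a saturated chain carbon bound to a sulfur. For the measured compounds named here, two measured steps bear on this change. The step of a 3.8-fold higher number from compound 2 to compound 3 (0.58 log units; beyond the scatter) shows that trifluoromethyl, set against hydrogen, goes with a modestly higher number, beyond the scatter. The step of a 1.9-fold higher number from compound 1 to compound 3 (0.28 log units; within the scatter), trifluoromethyl set against chloro, stays within the scatter. Going by the values given here, no measured compound carries a methyl group on that ring, so the only guidance is that removing trifluoromethyl has gone with a lower number. Compound 4 is therefore expected to show a 2.4-fold lower number from compound 3 to compound 4 (0.38 log units; beyond the scatter), landing in the region between the numbers of compound 2 and compound 3. Compound 4 is estimated at 8000 nM in this assay, with a range from 3000 nM to 25000 nM.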

Compound 4, half-maximal inhibitory concentration: 17000 nM
Compound 4: the middle estimate sits 2.1-fold (0.33 log units) below what was measured; low and high end bracket the measured number.
By their numbers in this assay, from the lowest: compounds 2, 1, 4 and 3 (each within the scatter of the next, the first and the last beyond it).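

In this assay, for the compounds shown here, the earlier compounds tied a higher number only to trifluoromethyl on the phenyl ring carried by the saturated chain carbon bound to a sulfur, but the methyl of compound 4 also goes with a modest rise beyond the scatter, a 3.4-fold higher number from compound 2 to compound 4 (0.53 log units; beyond the scatter). The rise is therefore not confined to trifluoromethyl, although the chloro of compound 1 goes against any rule that every group on this ring separates from hydrogen, since a 2.0-fold lower number from compound 1 to compound 2 (0.30 log units; within the scatter) stays within the scatter. The change from 3-(trifluoromethyl)phenyl to 4-methylphenyl, with 10 heavy atoms leaving and 7 entering, does not separate the two compounds, a 1.1-fold lower number from compound 3 to compound 4 (0.05 log units; within the scatter), and 4-methylphenyl likewise cannot be told apart from 3-chlorophenyl, a 1.7-fold higher number from compound 1 to compound 4 (0.23 log units; within the scatter).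

The compounds shown leave open whether a hydroxyl, an amine or a carboxylic acid on this ring would stay with these numbers, and, with each group shown on the ring at one place only, whether moving a group along the ring matters. Nothing shown gives a measured reason for any of these steps.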